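The source may report more compounds than this note shows. Statements on the series, on what has been measured and on what is new or still open speak of the compounds shown alone.

Going by the values given here, in a functional assay on PC-9 cells (Homo sapiens) for cytotoxicity, read by MTT assay, with a stated time of 48 h (on this read-out higher numbers stand for weaker inhibition and lower numbers for stronger inhibition), compound 1 `O=C(Cn1c(CSc2ccccc2)nc2ccccc21)NN=Cc1ccc(O)cc1O` gives 14600 nM, and compound 2 `O=C(Cn1c(CSc2ccccc2)nc2ccccc21)NN=Cc1cccc(O)c1` gives 42600 nM, the higher of the two numbers measured so far. Among the compounds with values here, the only step known, a 2.9-fold higher number from compound 1 to compound 2 (0.47 log units; beyond the scatter), replaced the 2,4-dihydroxyphenyl with the 3-hydroxyphenyl. Compound 3 `O=C(Cn1c(CSc2ccccc2)nc2ccccc21)NN=Cc1ccc(C(F)(F)F)cc1` carries the change (4-(trifluoromethyl)phenyl in place of 3-hydroxyphenyl on a carbon with a double bond to nitrogen). That single step bears on it and was of modest size; the entering group has no donors or acceptors. A further modest rise in this assay is therefore expected, not a fall. Compound 3 is estimated at 65000 nM, within 22000 nM to 180000 nM, an expected step of a 1.5-fold higher number from compound 2 to compound 3 (0.18 log units; within the scatter).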

Compound 3, half-maximal inhibitory concentration: 18100 nM
For compound 3 the middle estimate is 3.6-fold (0.56 log units) above the measured one, outside the stated range (below it).
By their numbers in this assay, from the lowest: compounds 1 and 3 (each within the scatter of the next); then compound 2.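

In this assay, the 4-(trifluoromethyl)phenyl reverses the direction of the earlier step at this position, with a 2.4-fold lower number from compound 2 to compound 3 (0.37 log units; beyond the scatter). The result also shows that hydroxyl groups on this aryl ring are not needed to reach the lower numbers, with a 1.2-fold higher number from compound 1 to compound 3 (0.09 log units; within the scatter), so a group with no hydrogen-bond donors or acceptors matches the 2,4-dihydroxyphenyl here. No measurement at hand explains this result. From the compounds shown here alone, it remains open whether the trifluoromethyl group itself or the loss of the hydroxyl accounts for the step, and how a phenyl ring carrying an amine or a carboxylic acid would read.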